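From 4-methoxybenzyl to 4-chlorobenzyl: notes on compound 3

The compounds below may be only part of what the source reports. "The series", "measured", "known", "first", "only" and "open" are said of these compounds alone.

Measured so far:
- compound 1 `COc1ccc(CN2C(=O)/C(=C\c3cc(OC)c(OC)c(OC)c3)c3ccccc32)cc1` gives 3600 nM
- compound 2 `COc1ccc2c(c1)/C(=C\c1cc(OC)c(OC)c(OC)c1)C(=O)N2C` gives 16600 nM

Both values come from a functional assay on cells (Cancer cell lines, Homo sapiens) for cytotoxicity, with a stated time of 48 h; a lower number here means a stronger inhibitor of growth, a higher number a weaker inhibitor of growth. Compound 1 holds the lower number of the two, and the gap to compound 2 lies beyond the usual scatter. Among the compounds with values here, the two compounds differ in more than one place, so the data hold no single-change step, and no measured step speaks directly to the next change.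

The next compound is compound 3 `COc1cc(/C=C2\C(=O)N(Cc3ccc(Cl)cc3)c3ccccc32)cc(OC)c1OC`. Its change from compound 1 is chloro in place of methoxy on an aromatic carbon, with chloro in place of methoxy on an aromatic carbon, para to a large group. The rest of the core of compound 1 stays the same. Within the data shown here, with no measured precedent for this swap, the expectation starts from compound 1 at 3600 nM, and no step beyond the scatter is expected in this assay, in either direction. The estimated change is a 1.1-fold higher number from compound 1 to compound 3 (0.05 log units; within the scatter). For compound 3 the expected value is 4000 nM, with an estimated range from 1400 nM to 12000 nM.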

Compound 3, concentration for total growth inhibition: 5900 nM
Compound 3: middle estimate off by 1.5-fold (0.17 log units), on the low side; low and high end bracket the measured number.
By their numbers in this assay, from the lowest: compounds 1 and 3 (each within the scatter of the next); then compound 2.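

Chloro in place of methoxy, on an aromatic carbon para to a large group, supplies the first single-change step of the series in this assay (a 1.6-fold higher number from compound 1 to compound 3 (0.21 log units; within the scatter)). At this place on the benzyl group, a methoxy with two heavy atoms and one hydrogen-bond acceptor can thus be exchanged for a chloro with one heavy atom and no hydrogen-bond acceptor while the number stays within the scatter of compound 1; compound 2 differs from both compound 1 and compound 3 in more than one place, so steps to it cannot be read. No measured evidence bears on this result or offers a reason for it.

On these data alone, the two groups seen at this place say nothing yet about an amine, a carboxylic acid or a longer alkoxy chain there, so it remains open how far the insensitivity seen between methoxy and chloro extends. Also open, as far as these compounds go, is whether the same exchange would stay within the scatter if made on a core carrying other groups elsewhere.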